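Replacing a nitrophenyl arm with an isopropyl group

The source may report more compounds than this note shows. Statements on the series, on what has been measured and on what is new or still open speak of the compounds shown alone.

Compound 1 `COc1ccc(N(Cc2ccccc2)CC(C)C)cc1` gives 10 ug/mL in a functional assay on L929 cells (Mus musculus) for inhibition, read by MTT assay, with a stated time of 5 days; a higher number here means a weaker inhibitor, a lower number a stronger inhibitor. Compound 2 `COc1ccc(N(Cc2ccc([N+](=O)[O-])cc2)Cc2ccccc2OC)cc1` reaches only a limit of this assay, > 40 ug/mL, so its true value is not known, as the limit of > 40 ug/mL in this assay, at which 1 of the 2 values shown sits, shows. Compound 3 `COc1ccc(N(Cc2ccccc2OC)CC(C)C)cc1` has not yet been tested. It differs from compound 2 by isopropyl in place of 4-nitrophenyl on a saturated chain carbon bound to a nitrogen on an aromatic ring. Compound 1 carries the same isopropyl on the same kind of chain carbon. On that basis compound 3 is expected to give a measurable number near that of compound 1, estimated at 12 ug/mL, between 5 ug/mL and 40 ug/mL. The expected step is an at least 3.3-fold lower number from compound 2 to compound 3 (0.52 log units; beyond the scatter).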

Compound 3, half-maximal inhibitory concentration: 15 ug/mL
Estimate against measurement, compound 3: 1.3-fold (0.10 log units) below, and the stated range covers the measured number.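

At this chain carbon, isopropyl in place of 4-nitrophenyl turns a reading at the limit into a measurable number in this assay, with an at least 2.6-fold lower number from compound 2 to compound 3 (0.42 log units; beyond the scatter). Going by these compounds, the true size of this step stays unknown, and only its lower bound can be read: the limit of > 40 ug/mL in this assay, at which 1 of the 3 values shown sits. Methoxy in place of hydrogen on an aromatic carbon makes no readable difference, with a 1.5-fold higher number from compound 1 to compound 3 (0.18 log units; within the scatter).

Still open, on these data alone, is whether isopropyl itself matters or whether removing the 4-nitrophenyl ring is enough. A longer chain or an amine on this carbon would help separate the two.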